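The source may hold more compounds than are shown below. What is called first, only, known or untested is meant among the compounds shown, and "the series" means these compounds.

Measured in a functional assay on PC-3 cells (Homo sapiens) for inhibition, with a stated time of 72 h; on this read-out lower numbers stand for stronger inhibition and higher numbers for weaker inhibition:
compound 1 `Cc1cc(Cl)ccc1NC(=O)Nc1nc(Sc2c[nH]c3ccccc23)cc(N2CCN(Cc3ccccc3)CC2)n1`: 22500 nM
compound 2 `COc1ccc(NC(=O)Nc2nc(Sc3c[nH]c4ccccc34)cc(N3CCN(Cc4ccccc4)CC3)n2)cc1`: 16700 nM

Among the measured compounds shown here, compound 1 stands at the highest of the two numbers in this assay; the only step, a 1.3-fold lower number from compound 1 to compound 2 (0.13 log units; within the scatter), lies within the scatter. Compound 3 `Cc1cc(Cl)ccc1NC(=O)Nc1nc(Sc2c[nH]c3ccccc23)cc(N2CCN(c3ccccn3)CC2)n1` differs from compound 1 by pyridin-2-yl in place of benzyl on an amine nitrogen in a ring. For the measured compounds named here, the one measured step concerns the group on an amide-type nitrogen, not the amine nitrogen in a ring, so no measured step bears on this change. With nothing to go on, no step beyond the scatter is expected: a 1.1-fold lower number from compound 1 to compound 3 (0.05 log units; within the scatter). Compound 3 is therefore estimated at 20000 nM, with a wide range from 5000 nM to 80000 nM.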

Compound 3, half-maximal inhibitory concentration: 19800 nM
The estimate for compound 3 lay 1.0-fold (0.00 log units) above the measured number, and the stated range covers the measured number.
By their numbers in this assay, from the lowest: compounds 2, 3 and 1 (each within the scatter of the next).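

At the amine nitrogen in the ring, the first read on this position gives a 1.1-fold lower number from compound 1 to compound 3 (0.06 log units; within the scatter) in this assay. Replacing benzyl, a carbon-only aromatic ring, with pyridin-2-yl, which brings a ring nitrogen and a hydrogen-bond acceptor, therefore leaves the number within the scatter. No supporting data bear on this result. Still open, going by these compounds, is whether a carboxylic acid, a primary amine or a longer alkyl chain on this nitrogen would give a step beyond the scatter. Also open, on these data alone, is how pyridin-2-yl behaves alongside the 4-methoxyphenyl group of compound 2.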